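This account rests on a few compounds, and the source may have more. Where it says the series, first, only, none or still open, it means among the compounds named here.

Measured so far in an ADME assay on liver (Mesocricetus auratus) for metabolic stability, using microsomes; a lower number here means slower removal, a higher number faster removal of the compound
compound 1 `O=C(Nc1cc(-c2ccccn2)n[nH]1)N1CCC(Oc2ccccc2)CC1` gives 98.5 mL.min-1.g-1
compound 2 `O=C(Nc1cc(-c2ccccn2)n[nH]1)N1CCC(c2ccc(Cl)cc2)CC1` gives 43.8 mL.min-1.g-1

Compound 2 has the lower of the two numbers. Among the measured compounds shown here, the only measured step is a 2.2-fold lower number from compound 1 to compound 2 (0.35 log units; beyond the scatter) and it places 4-chlorophenyl where phenoxy stood on a saturated ring carbon.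

Compound 3 `O=C(Nc1cc(-c2ccccn2)n[nH]1)N1CCC(Oc2ccccn2)CC1` differs from compound 2 as follows: (pyridin-2-yl)oxy in place of 4-chlorophenyl on a saturated ring carbon and this brings back a group joined through oxygen, as in compound 1.

For the measured compounds named here, the step from compound 1 is therefore the one measured guide, run in reverse. Going by the values given here, no measured compound carries (pyridin-2-yl)oxy, so only part of that step is expected to return, and compound 1 at 98.5 mL.min-1.g-1 serves as a loose upper guide. In this assay a rise is expected, with an estimated step of a 1.6-fold higher number from compound 2 to compound 3 (0.20 log units; within the scatter) as the working figure. For compound 3 the expected value is 70 mL.min-1.g-1 with an estimated range from 32 mL.min-1.g-1 to 140 mL.min-1.g-1 for now.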

Compound 3, intrinsic clearance in microsomes: 67.3 mL.min-1.g-1
Beside the measured number, compound 3's estimate is 1.0-fold (0.02 log units) above it; low and high end bracket the measured number.
By their numbers in this assay, from the lowest: compounds 2, 3 and 1 (each within the scatter of the next, the first and the last beyond it).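

In this assay the saturated ring carbon now carries a third group: (pyridin-2-yl)oxy in place of 4-chlorophenyl gives a 1.5-fold higher number from compound 2 to compound 3 (0.19 log units; within the scatter), and pyridin-2-yl in place of phenyl on the oxygen gives a 1.5-fold lower number from compound 1 to compound 3 (0.17 log units; within the scatter). Compound 3 thus lies within the scatter of both compounds that the earlier step set apart, and the ring nitrogen gives no reading distinct from the phenoxy group of compound 1. Nothing available accounts for these numbers at this position.

The compounds shown leave open how much of the gap between compound 1 and compound 2 belongs to the linking oxygen and how much to the chlorine, as that step changes both at once. A 4-chlorophenoxy group or a plain phenyl on this carbon would separate the two.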